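The source may hold more compounds than are shown below. What is called first, only, known or untested is meant among the compounds shown, and "the series" means these compounds.

Compound 1 `COc1cccc(-c2csc(N/N=C3\CCC(C)C3)n2)c1` is the weaker of the two measured compounds here: in an assay on isolated protein for inhibition of Amine oxidase [flavin-containing] A (Homo sapiens), read by fluorescence (on this read-out lower numbers stand for stronger inhibition and higher numbers for weaker inhibition), compound 1 gives 1450 nM, while compound 2 `COc1cccc(-c2csc(N/N=C/c3c[nH]c4ccccc34)n2)c1` gives 414 nM in this assay, a lower number that lies beyond the scatter of repeated measurements. Among the compounds with values here, no pair of measured compounds differing in a single place is available, so there is no measured step to lean on.

Compound 3 `CCC/C(C)=N/Nc1nc(-c2cccc(OC)c2)cs1` differs from compound 1 in one place: a group of 6 heavy atoms (5 carbon, 1 nitrogen; no ring) in place of a group of 7 heavy atoms (6 carbon, 1 nitrogen; one five-membered non-aromatic ring of carbon only), on a nitrogen on an aromatic ring. Both groups carry one double bond outside aromatic rings and one hydrogen-bond acceptor, so the exchange is modest in size.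

With nothing measured to calibrate it, the step is expected to be small, either none beyond the scatter or a slight move toward a higher number. In this assay compound 3 is accordingly estimated at 1900 nM, within 700 nM to 5000 nM, an expected step of a 1.3-fold higher number from compound 1 to compound 3 (0.12 log units; within the scatter).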

Compound 3, half-maximal inhibitory concentration: 1310 nM
The estimate for compound 3 lay 1.5-fold (0.16 log units) above the measured number, and the stated range covers the measured number.
By their numbers in this assay, from the lowest: compound 2; then compounds 3 and 1 (each within the scatter of the next).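

In this assay, the exchange of the group carrying the five-membered non-aromatic ring of carbon only for the group with no ring gives a 1.1-fold lower number from compound 1 to compound 3 (0.04 log units; within the scatter). Within the data shown here, this is the only measured step at this place, on a nitrogen on an aromatic ring, and it shows that, for this pair, the ring is not required to keep the number at the level of compound 1. The group of 7 heavy atoms and the group of 6 heavy atoms cannot be told apart in this assay, so this exchange gives no handle on inhibition, and no measured information is available to explain why the two groups read alike.

The compounds shown leave open whether the number at this place would move with a more different group, such as a longer chain or a chain ending in an amine or a carboxylic acid. A single step within the scatter also cannot show how far this place accepts change, or whether the same exchange would read alike on a different core.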